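The source may hold more compounds than are shown below. What is called first, only, known or untested is meant among the compounds shown, and "the series" means these compounds.

Compound 1 `COc1nc(C)cc(SC)c1NC(=O)N(Cc1ccc(Oc2ccc(F)cc2)cc1)C1CCCCCC1` gives 29 nM in an assay for inhibition of acyl-CoA:cholesterol acyltransferase (Oryctolagus cuniculus), using microsomes (a lower number here means a stronger inhibitor, a higher number a weaker inhibitor), the lowest of the three numbers measured. Compound 2 `Cc1cc(S(C)(=O)=O)c(NC(=O)N(Cc2ccc(Oc3ccc(F)cc3)cc2)C2CCCCCC2)c(S(C)(=O)=O)n1` gives 45 nM in this assay, within the scatter of compound 1. Compound 3 `CSc1cc(C)nc(C)c1NC(=O)N(Cc1ccc(Oc2ccc(F)cc2)cc1)C1CCCCCC1` gives 90 nM in this assay, and the step of a 3.1-fold higher number from compound 1 to compound 3 (0.49 log units; beyond the scatter) is a modest one. Compound 4 `COc1nc(C)ccc1NC(=O)N(Cc1ccc(Oc2ccc(F)cc2)cc1)C1CCCCCC1` differs from compound 1 by hydrogen in place of methylsulfanyl on an aromatic carbon. For the measured compounds named here, none of the measured steps bears on this change: the only single-point step swaps methyl for methoxy, and compound 2 differs from compound 1 in more than one place. With no direct guide, compound 4 is expected to fall near compound 1 or somewhat higher, a step of about a 2.1-fold higher number from compound 1 to compound 4 (0.32 log units; beyond the scatter). The estimate for compound 4 is 60 nM, between 20 nM and 200 nM.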

Compound 4, half-maximal inhibitory concentration: 39 nM
For compound 4 the middle estimate is 1.5-fold (0.19 log units) above the measured one, and the stated range covers the measured number.
By their numbers in this assay, from the lowest: compounds 1, 4, 2 and 3 (each within the scatter of the next, the first and the last beyond it).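

In this assay hydrogen in place of the methylsulfanyl group opposite the ring nitrogen gives a 1.3-fold higher number from compound 1 to compound 4 (0.13 log units; within the scatter), so the two numbers lie within the scatter of each other. The step of a 2.3-fold lower number from compound 3 to compound 4 (0.36 log units; beyond the scatter) changes two places on the ring at once and cannot be read as a single change. No measurement on hand explains the result. Still open, from the compounds shown here alone, is whether an amine, a chlorine atom or a longer chain at this position would leave the number unchanged, and whether hydrogen is equally acceptable with methyl in place of the methoxy group.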